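The source may report more compounds than this note shows. Statements on the series, on what has been measured and on what is new or still open speak of the compounds shown alone.

Four compounds share one core. Compound 1 `CN1CCN(c2nc3ccccc3n2CCO)CC1` gives 410 nM in a functional assay on ileum for inhibition of histamine H1 receptor (Cavia porcellus); a higher number here means a weaker inhibitor, a lower number a stronger inhibitor. Compound 2 `CCCCCCn1c(N2CCN(C)CC2)nc2ccccc21` gives 26 nM in this assay, and compound 3 `CCCCCCCCCCn1c(N2CCN(C)CC2)nc2ccccc21` gives 4200 nM in this assay. Compound 3 thus has the highest number of the three, beyond the scatter from both of the others: a 10-fold higher number from compound 1 to compound 3 (1.01 log units; beyond the scatter), and a 160-fold higher number from compound 2 to compound 3 (2.21 log units; beyond the scatter). The unmeasured compound 4 `CN1CCN(c2nc3ccccc3n2CCOCCO)CC1` differs from compound 3 in one place: 2-hydroxyethoxy in place of octyl on a saturated chain carbon, two bonds along the chain from an aromatic nitrogen. Among the measured compounds shown here, two measured steps bear on this change, both at the same place on the chain: a 16-fold lower number from compound 1 to compound 2 (1.20 log units; beyond the scatter) and a 10-fold higher number from compound 1 to compound 3 (1.01 log units; beyond the scatter). The move to compound 4 removes the octyl of compound 3 and puts in its place a group that, like the hydroxy of compound 1, carries a hydrogen-bond donor, so the number is expected to move back toward that of compound 1, and a fall is expected, an 11-fold lower number from compound 3 to compound 4 (1.02 log units; beyond the scatter). Compound 4 is accordingly estimated at 400 nM in this assay, within 120 nM to 1300 nM. The longer chain of compound 4 against compound 1 has no measured counterpart among these compounds, so the range is kept wide.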

Compound 4, half-maximal inhibitory concentration: 42 nM
Compound 4: middle estimate off by 9.5-fold (0.98 log units), on the high side, outside the stated range (below it).
By their numbers in this assay, from the lowest: compounds 2 and 4 (each within the scatter of the next); then compound 1; then compound 3.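

Putting a 2-hydroxyethyl on the oxygen of compound 1 gives a 9.8-fold lower number from compound 1 to compound 4 (0.99 log units; beyond the scatter) in this assay and shows that a group with a hydrogen-bond donor at this place is not tied to the number of compound 1. With 2-hydroxyethoxy in place of butyl there is a 1.6-fold higher number from compound 2 to compound 4 (0.21 log units; within the scatter) and so the two groups cannot be told apart in this assay, which means that the low number of compound 2 is no longer confined to a group of carbon alone. With 2-hydroxyethoxy in place of octyl the change is a 100-fold lower number from compound 3 to compound 4 (2.00 log units; beyond the scatter) and this large step shows that the high number of compound 3 is not shared by every longer substituent at this place, since the chain of compound 4 also extends beyond that of compound 1. As far as these compounds go, it stays open whether an amine, a carboxylic acid, a methoxy-capped ethoxy chain or a longer chain of repeating ethoxy units in place of 2-hydroxyethoxy would keep the number near that of compound 4. Nothing among the data shown accounts for these steps.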